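A limit-bound series meets 2,4-dimethoxyphenyl

This account rests on a few compounds, and the source may have more. Where it says the series, first, only, none or still open, it means among the compounds named here.

Compounds measured in a functional assay on HOS cells (Homo sapiens) for antiproliferative activity, with a stated time of 72 h (a lower number here means a stronger inhibitor, a higher number a weaker inhibitor), and their limits
- Compound 1 `OC[C@H]1O[C@@H](n2cnc3c(NCc4ccc(Cl)cc4)ncnc32)[C@H](O)[C@@H]1O` gives > 166000 nM as a limit
- Compound 2 `Cc1ccc(CNc2ncnc3c2ncn3[C@@H]2O[C@H](CO)[C@@H](O)[C@H]2O)cc1` gives > 166000 nM as a limit
- Compound 3 `OC[C@H]1O[C@@H](n2cnc3c(NCc4ccc(Cl)cc4Cl)ncnc32)[C@H](O)[C@@H]1O` gives > 166000 nM as a limit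

Compound 3 has no number, only a limit, and it shares that position with the whole set, as the limit of > 166000 nM in this assay, at which 3 of the 3 values shown sit, shows. Compound 4 `COc1ccc(CNc2ncnc3c2ncn3[C@@H]2O[C@H](CO)[C@@H](O)[C@H]2O)c(OC)c1` has 2,4-dimethoxyphenyl in place of 2,4-dichlorophenyl on a saturated chain carbon bound to a nitrogen on an aromatic ring, a difference counted as 2,4-dimethoxyphenyl in place of 2,4-dichlorophenyl on a saturated chain carbon bound to a nitrogen on an aromatic ring in full. The measured steps that bear on it are a step that the two limits leave unreadable from compound 2 to compound 3 and a step that the two limits leave unreadable from compound 1 to compound 3 and a step that the two limits leave unreadable from compound 1 to compound 2 and none gives a size to carry over. In this assay no step beyond the scatter is therefore expected, and no direction can be argued. The expected step is a number no higher from compound 3 to compound 4 (the limit leaves the size open) on this reading. For compound 4 the estimated value is 166000 nM with an expected range from 80000 nM to 300000 nM and quite possibly only a limit again.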

Compound 4, half-maximal inhibitory concentration: > 166000 nM
Compound 4 ended at the assay's limit; the forecaster's own chance of this, stated with the estimate: 85%; the middle value lies on the limit itself.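

No step can be read from compound 1, compound 2 or compound 3 to compound 4, since all four stand at one limit: the limit of > 166000 nM in this assay, at which 4 of the 4 values shown sit.

The compounds shown leave open what any of their actual values is and whether changing the aromatic group alters them.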